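Aryl for alkyl on the benzimidazole chain carbon of compound 3

A few compounds are considered here, and "the series" means these few. Any claim that something is new, unique, unknown or untested is made for them only; others in the source may bear on it.

Three compounds share one core and differ at two places. Compound 1 `O=C(C1CC1)N1CCN(Cc2nc3ccccc3n2Cc2ccccc2F)CC1` gives 40.7% in an assay on isolated protein for inhibition of aldehyde dehydrogenase 1A1 (Homo sapiens), read by spectrophotometry, tested at 10 uM; a lower number here means less inhibition, a higher number more inhibition at the concentration tested (going by the name of the read-out). Compound 2 `CC(C)CCn1c(CN2CCN(C(=O)c3ccco3)CC2)nc2ccccc21` gives 42.1% in this assay. Compound 3 `CC(C)CCn1c(CN2CCN(C(=O)C3CC3)CC2)nc2ccccc21` gives 70% in this assay, the highest of the three numbers, and both of its neighbours lie beyond the scatter below it: a number 29.3 percentage points higher from compound 1 to compound 3 (beyond the scatter) and a number 27.9 percentage points higher from compound 2 to compound 3 (beyond the scatter).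

Compound 4 `Cc1ccccc1Cn1c(CN2CCN(C(=O)C3CC3)CC2)nc2ccccc21` is not yet measured. It differs from compound 3 in one place: 2-methylphenyl in place of isobutyl on a saturated chain carbon bound to an aromatic nitrogen. For the measured compounds named here, the step that bears on this is the one from compound 1 to compound 3, where an isobutyl replaced a 2-fluorophenyl on the same saturated chain carbon and gave a number 29.3 percentage points higher from compound 1 to compound 3 (beyond the scatter). The change to compound 4 runs the other way, from isobutyl back to a six-membered aromatic ring of carbon only, so a drop of a comparable size is expected, though a 2-methylphenyl is not a 2-fluorophenyl and the two measured compounds give no direct reading of that difference.

Compound 4 is therefore expected to give 45% in this assay, in the range 25% to 65%, an expected step of a number 25 percentage points lower from compound 3 to compound 4 (beyond the scatter).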

Compound 4, a percentage reported as inhibition, at one concentration (the size of the read-out at that concentration, not a potency): 29.1%
The estimate for compound 4 lay 15.9 percentage points above the measured number; measured number inside the range.
By their numbers in this assay, from the lowest: compound 4; then compounds 1 and 2 (each within the scatter of the next); then compound 3.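

The second aromatic group confirms what compound 1 suggested: in this assay, the isobutyl of compound 3 stands beyond the scatter above both ring-bearing compounds, and the loss on moving to 2-methylphenyl is a number 40.9 percentage points lower from compound 3 to compound 4 (beyond the scatter), a large step. For the compounds shown here, the substituent on the aromatic ring also matters, which the earlier compounds could not show: with the rest of the molecule held constant, methyl in place of fluoro gives a number 11.6 percentage points lower from compound 1 to compound 4 (beyond the scatter), so the two aromatic groups are not interchangeable, although that step is only modest. Across these compounds, then, the chain carbon bound to the aromatic nitrogen carries the isobutyl as the best of the three groups seen there, while no measurement shown accounts for the differences among them.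

As far as these compounds go, it remains open whether an unsubstituted phenyl, a chloro on the same aromatic carbon or a saturated cyclohexyl ring would sit nearer compound 3 or compound 4, and whether a longer chain would improve on isobutyl. From the compounds shown here alone, it is also open whether furan-2-yl on the carbonyl carbon would lower the number with 2-methylphenyl in place as it does with isobutyl.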